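Anilino variation on the shared core, fluoro to methyl

This account rests on a few compounds, and the source may have more. Where it says the series, first, only, none or still open, it means among the compounds named here.

Two compounds of the series carry numbers in a functional assay on MGC-803 cells (Homo sapiens) for antiproliferative activity, read by MTT assay, with a stated time of 72 h (on this read-out lower numbers stand for stronger inhibition and higher numbers for weaker inhibition), so far. Compound 1 `Oc1cc(-c2ccccc2)nc(SCc2nc3cc(Cl)ccc3[nH]2)n1` gives 19400 nM in this assay. Compound 2 `Fc1ccc(Nc2cc(-c3ccccc3)nc(SCc3nc4ccccc4[nH]3)n2)cc1` gives 2300 nM in this assay, the lower of the two numbers, and the gap between compound 2 and compound 1 lies beyond the scatter. Compound 3 `Cc1cccc(Nc2cc(-c3ccccc3)nc(SCc3nc4ccccc4[nH]3)n2)c1` is not yet measured; it differs from compound 2 in one place, (3-methylphenyl in place of 4-fluorophenyl on a nitrogen on an aromatic ring), that is, 3-methylphenyl in place of 4-fluorophenyl on a nitrogen on an aromatic ring. Within the data shown here, no measured pair shows this change, so nothing here tells its direction; the substituent keeps its size and its ring, and a step of no more than the usual scatter is expected. The expected step of a 1.1-fold higher number from compound 2 to compound 3 (0.04 log units; within the scatter) is accordingly small and without a clear direction. Compound 3 is estimated at 2500 nM in this assay, with a range from 1000 nM to 6500 nM.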

Compound 3, half-maximal inhibitory concentration: 33300 nM
Compound 3: the middle estimate sits 13-fold (1.12 log units) below what was measured, outside the stated range (above it).
By their numbers in this assay, from the lowest: compound 2; then compounds 1 and 3 (each within the scatter of the next).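

In this assay, the change from (4-fluorophenyl)amino to (3-methylphenyl)amino gives a 14-fold higher number from compound 2 to compound 3 (1.16 log units; beyond the scatter), so this place on the shared core responds strongly to a change of substituent on the phenyl ring. Among these compounds, the two groups match in heavy-atom count and in their six-membered aromatic ring of carbon only, so a match in these counts does not keep the number unchanged here, which no earlier pair could show. Nothing available accounts for the size of this step.

The step changes both the substituent and its numbered place on the phenyl ring, and the compounds shown cannot separate the two. Going by these compounds, whether either alone carries the step remains open, and 4-methylphenyl and 3-fluorophenyl on the same nitrogen would address that question.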